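Adding a methyl to the isopropylamino chain of compound 3

The source may hold more compounds than are shown below. What is called first, only, known or untested is meant among the compounds shown, and "the series" means these compounds.

The three measured compounds share a core and differ in the group on the ring nitrogen that carries the amine. Compound 1 `Cc1nc(Nc2ccccc2)c2cc[nH]c2n1` carries a phenyl there, compound 2 `CCCNc1[nH]c(C)nc2nccc1-2` a propyl, and compound 3 `Cc1nc2nccc-2c(NC(C)C)[nH]1` an isopropyl. In a functional assay on the whole organism for inhibition, with Nicotiana tabacum as the target (a lower number here means a stronger inhibitor, a higher number a weaker inhibitor), compound 1 gives 550000000 nM, compound 2 gives 339000000 nM, and compound 3 gives 550000000 nM. Going by the values given here, compound 3 thus stands level with compound 1 and, together with it, at the highest numbers of the three, while compound 3 and compound 2 lie within the scatter of each other; the only step between neighbours, a 1.6-fold higher number from compound 2 to compound 3 (0.21 log units; within the scatter), is within the scatter.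

Compound 4 `CCC(C)Nc1[nH]c(C)nc2nccc1-2` differs from compound 3 by methyl in place of hydrogen on a saturated chain carbon, two bonds along the chain from a nitrogen on an aromatic ring. Among the compounds with values here, the one step that bears on it is the chain variation a 1.6-fold higher number from compound 2 to compound 3 (0.21 log units; within the scatter), which changed the number by no more than the usual scatter. On that basis the additional methyl is expected to leave this assay essentially unchanged, with no step beyond the scatter in either direction, that is no change at the digits printed from compound 3 to compound 4 (within the scatter). Compound 4 is therefore estimated at 550000000 nM, with a range from 250000000 nM to 1200000000 nM.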

Compound 4, half-maximal inhibitory concentration: 174000000 nM
For compound 4 the middle estimate is 3.2-fold (0.50 log units) above the measured one; measured number outside the range, below it.
By their numbers in this assay, from the lowest: compounds 4, 2, 1 and 3 (each within the scatter of the next, the first and the last beyond it).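

In this assay, methyl in place of hydrogen on a saturated chain carbon, two bonds along the chain from a nitrogen on an aromatic ring, gives a 3.2-fold lower number from compound 3 to compound 4 (0.50 log units; beyond the scatter) and is the only step among these compounds that goes beyond the scatter, a modest one, so turning isopropylamino into (sec-butyl)amino does register in this assay, where the earlier change from propyl to isopropyl did not. The comparison with the straight chain is less clear, since a 1.9-fold lower number from compound 2 to compound 4 (0.29 log units; within the scatter) stays within the scatter and leaves compound 4 and compound 2 unseparated, so the result sets the sec-butyl chain apart from the isopropyl chain but not from the propyl chain. Nothing available accounts for this step or explains it.

On these data alone, whether a longer chain at this carbon, such as an ethyl in place of the new methyl, or a hydroxyl group there, would carry the number further in the same direction stays open. Also open, as far as these compounds go, is whether the same methyl would have any comparable effect on a cyclic group on the amine nitrogen, such as cyclopentyl, since the phenyl of compound 1 is the only ring in that place.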